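A few compounds are considered here, and "the series" means these few. Any claim that something is new, unique, unknown or untested is made for them only; others in the source may bear on it.

Compound 1, `NCCNc1cc(N2CCN(C(=O)CCc3ccccc3)CC2)nc2ccccc12`, gives > 100000 nM in an ADME assay on HEp-2 cells (Homo sapiens) for cytotoxicity, read by CCK-8 assay, with a stated time of 6 days (a lower number here means that less compound is tolerated, a higher number that more compound is tolerated), a limit of the assay.
Compound 2, `CS(=O)(=O)N1CCN(c2cc(NCCN)c3ccccc3n2)CC1`, gives > 100000 nM in this assay, also a limit.

Compound 2 thus stands at the limit of > 100000 nM in this assay, at which 2 of the 2 values shown sit, and the step that the two limits leave unreadable from compound 1 to compound 2 cannot be read. Compound 3, `CC(=O)N1CCN(c2cc(NCCN)c3ccccc3n2)CC1`, differs from compound 2 by acetyl in place of methylsulfonyl on an amine nitrogen in a ring. Among the compounds with values here, the one measured step bears on this change only as two limits, so no step beyond the scatter is expected in this assay. Compound 3 is therefore estimated at 150000 nM, within 50000 nM to 500000 nM, an expected step that the limit leaves unreadable from compound 2 to compound 3, most likely again reported only as a limit.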

Compound 3, half-maximal cytotoxic concentration: > 100000 nM
Compound 3 gave a limit, no number (the forecaster's own chance of this, stated with the estimate: 85%); the middle value lies beyond the limit too.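

Compound 3 gives only a limit, as do compound 1 and compound 2, so no step among these compounds can be read in this assay: the limit of > 100000 nM in this assay, at which 3 of the 3 values shown sit.

The compounds shown leave open whether any group on the ring amine nitrogen would give a number rather than a limit in this assay.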